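A methoxy group added to compound 3

This account rests on a few compounds, and the source may have more. Where it says the series, first, only, none or still open, it means among the compounds named here.

In a functional assay on SW-620 cells (Homo sapiens) for inhibition, read by sulforhodamine B assay, with a stated time of 48 h, tested at 10 uM (a higher number here means more inhibition of growth at the concentration tested, a lower number less inhibition of growth), compound 1 `COc1ccc(-c2nc3sc(-c4ccccc4)cn3n2)cc1` gives 64% of inhibition, compound 2 `COc1cc(-c2nc3sc(-c4ccccc4)cn3n2)cc(OC)c1OC` gives 6% of inhibition and compound 3 `Clc1ccc(-c2cn3nc(-c4ccccc4)nc3s2)cc1` gives 13% of inhibition. Compound 3 therefore stands level with compound 2 within the usual scatter of repeated measurements, while compound 1 lies well above it, beyond that scatter.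

Compound 4 `COc1ccc(-c2nc3sc(-c4ccc(Cl)cc4)cn3n2)cc1` is built from compound 3 by one change, and that change is methoxy in place of hydrogen on an aromatic carbon with methoxy in place of hydrogen on an aromatic carbon. For the measured compounds named here, no measured pair shows this change alone, so the evidence is indirect. Compound 1 also bears a methoxy group and gives 64% of inhibition, which points upward. Compound 2 also bears methoxy groups, yet gives 6% of inhibition, so it goes against any simple rule and the uncertainty stays wide.

The expected move is upward, an estimated step of a number 32 percentage points higher from compound 3 to compound 4 (beyond the scatter) that would lie beyond the scatter. For compound 4 the estimate is 45% of inhibition, with a range from 15% to 75% expected.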

Compound 4, percent growth inhibition at one concentration: 40.4%
Beside the measured number, compound 4's estimate is 4.6 percentage points above it; the range from low to high includes it.
By their numbers in this assay, from the lowest: compounds 2 and 3 (each within the scatter of the next); then compound 4; then compound 1.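

Methoxy in place of hydrogen on an aromatic carbon now has a direct pair behind it in this assay: the step (a number 27.4 percentage points higher from compound 3 to compound 4 (beyond the scatter)) shows that this one group, para to a large group, raises growth inhibition in a compound that also carries chloro. Chloro in place of hydrogen on an aromatic carbon can also be read directly for the first time (a number 23.6 percentage points lower from compound 1 to compound 4 (beyond the scatter)), so on the methoxy-bearing compound chloro lowers the number, though compound 4 keeps much of the gain. Nothing measured here explains either step.

Going by these compounds, whether a hydroxyl group, an amine or a longer chain such as ethoxy would do as well as methoxy at this place remains open. On these data alone, it is also open whether the methoxy gain would persist with a group such as fluoro or methyl in place of chloro.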